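Swapping Methoxy for Chloro on Compound 1

The compounds below may be only part of what the source reports. "The series", "measured", "known", "first", "only" and "open" are said of these compounds alone.

In an ADME assay on microsomes from liver (Mus musculus) for metabolic stability (a higher number here means that the compound lasts longer, a lower number that the compound disappears faster), compound 1 (`COc1ccc(-c2cnc(NC(=O)c3ncc[nH]3)n2C)cc1`) gives 0.05 h, and compound 2 (`COc1ccc(-c2cnc(NC(=O)c3ccc(F)cc3)n2C)cc1`) gives 0.0667 h. Among the compounds with values here, these two numbers lie within the scatter of each other, so compound 1 stands level with the only other measured compound. Compound 3 (`Cn1c(-c2ccc(Cl)cc2)cnc1NC(=O)c1ncc[nH]1`) keeps the core of compound 1 but carries chloro in place of methoxy on an aromatic carbon, para to a large group: chloro in place of methoxy on an aromatic carbon. Within the data shown here, the only measured step, a 1.3-fold higher number from compound 1 to compound 2 (0.13 log units; within the scatter), replaced 1H-imidazol-2-yl with 4-fluorophenyl on a carbonyl carbon, so it was made at a different place. No measurement tests the new swap directly, which leaves that step as weak guidance. The expected change is small and, if anything, upward: a 1.8-fold higher number from compound 1 to compound 3 (0.26 log units; within the scatter). For compound 3 the estimated value is 0.09 h, with an expected range from 0.04 h to 0.25 h.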

Compound 3, half-life in the Mus musculus assay: 0.717 h
The estimate for compound 3 lay 8.0-fold (0.90 log units) below the measured number; the measured number lies above the stated range.
By their numbers in the Mus musculus assay, from the lowest: compounds 1 and 2 (each within the scatter of the next); then compound 3.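

Chloro in place of methoxy on an aromatic carbon, para to a large group, gives in the Mus musculus assay a 14-fold higher number from compound 1 to compound 3 (1.16 log units; beyond the scatter), so this position has a large bearing on how long the compound lasts, whereas the one earlier step, made at a different place, stayed within the scatter. In a physicochemical assay for solubility, read by nephelometry, measured as kinetic solubility, at pH 2.0 (on this read-out higher numbers stand for higher solubility and lower numbers for lower solubility), compound 1 gives > 100 ug/mL, which is a limit of the assay and not a number. In the physicochemical assay compound 3 gives 50 ug/mL. In the physicochemical assay the step reads an at least 2.0-fold lower number from compound 1 to compound 3 (0.30 log units; that floor lies within the scatter), its true size staying open because it starts from a limit: the limit of > 100 ug/mL in the physicochemical assay, at which 1 of the 2 values shown sits.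

From the compounds shown here alone, it remains open whether the rise follows from chloro entering or from methoxy leaving, which a fluoro or methyl group on this carbon could help separate. Also open, going by these compounds, is whether the same swap would act alike on compound 2, with its 4-fluorophenyl group on the carbonyl carbon.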